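Compound 1 and the loss of its sulfonyl side chain

The source may hold more compounds than are shown below. What is called first, only, known or untested is meant among the compounds shown, and "the series" means these compounds.

Measured so far in a physicochemical assay for lipophilicity; on this read-out higher numbers stand for higher lipophilicity and lower numbers for lower lipophilicity:
- compound 1 `CC(C)(c1cc([C@@]23CCOC[C@@H]2C3)nc(-c2cccc(O)c2)n1)S(C)(=O)=O` gives 4.8
- compound 2 `CCNC(=O)Nc1ccc(-c2nc(CS(C)(=O)=O)cc([C@]34CCOC[C@H]3C4)n2)cc1` gives 3.6
- compound 3 `CNCC(=O)Nc1ccc(-c2nc(CS(C)(=O)=O)cc([C@@]34CCOC[C@@H]3C4)n2)cc1` gives 3.1

Compound 1 holds the highest number of the three, with compound 2 and compound 3 both lower by more than the scatter. Compound 4 `Oc1cccc(-c2nccc([C@@]34CCOC[C@@H]3C4)n2)c1` has not yet been measured. It departs from compound 1 in one place, with hydrogen in place of 1-methyl-1-(methylsulfonyl)ethyl on an aromatic carbon, while the 3-hydroxyphenyl group and the rest of the core stay as they are.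

Going by the values given here, no measured pair isolates this change: compound 2 and compound 3 differ from compound 1 in more than one place. The expectation is therefore loose. Starting from compound 1 (4.8), a modest downward step is expected in this assay, and it may not clear the scatter. The estimated move is a number 0.40 log units lower from compound 1 to compound 4 (beyond the scatter) in this read-out. For compound 4 the expected value is 4.4 (estimated range 3.6 to 5.1).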

Compound 4, partition coefficient: 4
Compound 4: the middle estimate sits 0.40 log units above what was measured, and the stated range covers the measured number.
By their numbers in this assay, from the lowest: compound 3; then compound 2; then compound 4; then compound 1.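

In this assay, going by these compounds alone, hydrogen in place of 1-methyl-1-(methylsulfonyl)ethyl on the aromatic carbon gives a number 0.80 log units lower from compound 1 to compound 4 (beyond the scatter) and is the first step that isolates a single change. With the 3-hydroxyphenyl group and the rest of the core held constant, the whole step belongs to this one place, so the read-out is not indifferent to what stands on this carbon. Nothing measured here accounts for the direction or size of the step.

The compounds shown leave open which part of the departing group goes with the step, the methylsulfonyl or the two methyl groups on the linking carbon. Also open, from the compounds shown here alone, is where a methyl group, an amine or a carboxylic acid on this carbon would fall relative to compound 4 and compound 1.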